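The source may hold more compounds than are shown below. What is called first, only, known or untested is meant among the compounds shown, and "the series" means these compounds.

Working notes on the series. For the measured compounds named here, in a functional assay on BE(2)-C cells (Homo sapiens) for inhibition, read by MTT assay, with a stated time of 72 h (a lower number here means a stronger inhibitor of growth, a higher number a weaker inhibitor of growth), compound 3 `O=S(=O)(NCCCNCc1cccc(Cl)c1)c1cc(C(F)(F)F)cc(C(F)(F)F)c1` gives 6900 nM, the highest number among the three compounds measured so far. Compound 1 `O=S(=O)(NCCCNCc1cccc2ccccc12)c1cc(C(F)(F)F)cc(C(F)(F)F)c1` gives 2700 nM and compound 2 `O=S(=O)(NCCNCc1ccc(-c2ccccc2)cc1)c1cc(C(F)(F)F)cc(C(F)(F)F)c1` gives 2700 nM. Going by the values given here, the single step leading into compound 3, a 2.6-fold higher number from compound 1 to compound 3 (0.41 log units; beyond the scatter), replaced a larger aromatic group by a halogen-bearing phenyl. Compound 4 `O=S(=O)(NCCCNCc1ccc(Br)cc1)c1cc(C(F)(F)F)cc(C(F)(F)F)c1` differs from compound 3 by 4-bromophenyl in place of 3-chlorophenyl on a saturated chain carbon bound to an amine nitrogen. Among the compounds with values here, no measured step swaps one halogen-bearing phenyl for another, so the one step ending at compound 3 does not bear directly on this change, and no step beyond the scatter is expected in this assay. Compound 4 is therefore estimated at 5000 nM, with a range of 2200 nM to 11000 nM, meaning an expected step of a 1.4-fold lower number from compound 3 to compound 4 (0.14 log units; within the scatter).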

Compound 4, concentration for 50% growth inhibition: 2700 nM
Compound 4: middle estimate off by 1.9-fold (0.27 log units), on the high side, within the range that was stated.
By their numbers in this assay, from the lowest: compounds 1, 2 and 4 (each within the scatter of the next); then compound 3.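

At this position, on a saturated chain carbon bound to an amine nitrogen, exchanging one halogen-bearing phenyl for another is not silent in this assay (a 2.6-fold lower number from compound 3 to compound 4 (0.41 log units; beyond the scatter)). The 4-bromophenyl group also reads level with naphthalen-1-yl (no change at the digits printed from compound 1 to compound 4 (within the scatter)), so a phenyl group here does not by itself give the higher number, and compound 3 alone stands apart. Nothing on hand accounts for this step.

The halogen and its ring position change together, so their contributions cannot be separated. From the compounds shown here alone, how 4-chlorophenyl, 3-bromophenyl or unsubstituted phenyl would read here remains open.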